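From compound 1 to compound 4: an aryl exchange

The source may hold more compounds than are shown below. What is called first, only, known or untested is meant among the compounds shown, and "the series" means these compounds.

Measured so far:
compound 1, `Nc1scc(CN2CCN(c3ccc(Cl)cc3Cl)CC2)c1C(=O)c1ccc(Cl)cc1`: -74%
compound 2, `Nc1scc(CN2CCN(c3ccc(Cl)cc3F)CC2)c1C(=O)c1ccc(Cl)cc1`: -81%
compound 3, `Nc1scc(CN2CCN(c3cccc(F)c3)CC2)c1C(=O)c1ccc(Cl)cc1`: -82%

In a functional assay on CHO cells with adenosine receptor A1 (Homo sapiens) as the target, read by cAMP accumulation and immunoassay, with a stated time of 6 min, tested at 10 uM (a lower number here means a stronger effect, a higher number a weaker effect of the compound at the concentration tested), compound 1 gives the highest of the three numbers, yet its two neighbours lie close: the step of a number 7 percentage points lower from compound 1 to compound 2 (within the scatter) and the step of a number 8 percentage points lower from compound 1 to compound 3 (within the scatter) are both within the scatter, so the three compounds cannot be ranked against one another.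

Compound 4, `Nc1scc(CN2CCN(c3cc(F)ccc3F)CC2)c1C(=O)c1ccc(Cl)cc1`, is not yet measured. It differs from compound 1 in one place: 2,5-difluorophenyl in place of 2,4-dichlorophenyl on an amine nitrogen in a ring.

For the measured compounds named here, two measured steps bear on this change. The exchange of one aryl group for another on the ring nitrogen, seen in the step of a number 8 percentage points lower from compound 1 to compound 3 (within the scatter), and the swap of fluoro for chloro in the step of a number 7 percentage points lower from compound 1 to compound 2 (within the scatter), both stayed within the scatter; the step of a number 1 percentage points lower from compound 2 to compound 3 (within the scatter) did as well. On that basis no step beyond the scatter is expected in this assay for compound 4.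

Compound 4 is therefore estimated at -78%, with a range from -92% to -64%.

The expected step is a number 4 percentage points lower from compound 1 to compound 4 (within the scatter), which would sit within the scatter.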

Compound 4, a percentage reported as activity, at one concentration (the size of the read-out at that concentration, not a potency): -80%
Estimate against measurement, compound 4: 2 percentage points above; low and high end bracket the measured number.
By their numbers in this assay, from the lowest: compounds 3, 2, 4 and 1 (each within the scatter of the next).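

In this assay, replacing 2,4-dichlorophenyl with 2,5-difluorophenyl on the amine nitrogen in the ring exchanges both halogens in one change, and the result is a number 6 percentage points lower from compound 1 to compound 4 (within the scatter). Fluoro in place of hydrogen on an aromatic carbon gives a number 2 percentage points higher from compound 3 to compound 4 (within the scatter), and 2,5-difluorophenyl in place of 4-chloro-2-fluorophenyl gives a number 1 percentage points higher from compound 2 to compound 4 (within the scatter), so each of these exchanges at this position stays within the scatter, and the four compounds cannot be ranked. No measurement is available to explain this outcome.

All the aryl groups shown carry only chloro or fluoro, so it remains open whether a methoxy, trifluoromethyl or amino group at this position would also stay within the scatter. As far as these compounds go, as the read-out comes from a single concentration, any difference in potency among the four compounds also remains open.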